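Methoxy to dimethylamino on the aryl group of compound 1

A few compounds are considered here, and "the series" means these few. Any claim that something is new, unique, unknown or untested is made for them only; others in the source may bear on it.

Measured so far:
compound 1, `CCOC(=O)c1cnn(-c2nc(-c3ccc(OC)cc3)c(C#N)c(=O)n2C)c1N`: 79 ug/mL
compound 2, `CSc1nc(-c2ccccc2O)c(C#N)c(=O)n1C`: 58 ug/mL

In a functional assay, with a stated time of 150 min (on this read-out lower numbers stand for stronger inhibition and higher numbers for weaker inhibition), compound 1 gives 79 ug/mL and compound 2 gives 58 ug/mL; the two numbers lie within the scatter of each other, so neither compound can be called the more potent, and compound 1 is simply one of two weak inhibitors in this assay. For the measured compounds named here, no step between measured compounds is available, as compound 1 and compound 2 differ in more than one place.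

Compound 3, `CCOC(=O)c1cnn(-c2nc(-c3ccc(N(C)C)cc3)c(C#N)c(=O)n2C)c1N`, is not yet measured. It differs from compound 1 by dimethylamino in place of methoxy on an aromatic carbon. Nothing measured here speaks to what such a swap does on this core, so a step of no more than the scatter, in either direction, is expected; the numbers shown for compound 1 and compound 2 suggest that the series as a whole sits in a weak range. Compound 3 is therefore expected at 70 ug/mL, with a range from 30 ug/mL to 160 ug/mL. The step from compound 1 to compound 3 that this estimate implies is a 1.1-fold lower number from compound 1 to compound 3 (0.05 log units; within the scatter).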

Compound 3, half-maximal inhibitory concentration: 115 ug/mL
Compound 3: the middle estimate sits 1.6-fold (0.22 log units) below what was measured, within the range that was stated.
By their numbers in this assay, from the lowest: compounds 2, 1 and 3 (each within the scatter of the next).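

In this assay, for the compounds shown here, dimethylamino in place of methoxy on the aromatic carbon gives a 1.5-fold higher number from compound 1 to compound 3 (0.16 log units; within the scatter) and so provides a first reading of this position, which compound 1 and compound 2 could not give because they differ in more than one place. On this single step, 4-methoxyphenyl and 4-(dimethylamino)phenyl cannot be told apart, and compound 3 stays in the same weak range as compound 1. No measured finding bears on why the two groups read alike.

From the compounds shown here alone, it remains open whether a group of another kind on this aromatic carbon, such as a carboxylic acid or a primary amine, would give a step beyond the scatter. Going by these compounds, whether a hydrogen or a longer alkoxy chain at this place would do so is equally open.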